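Swapping an acetyl for a dimethoxyphenyl on the coumarin-like core

A few compounds are considered here, and "the series" means these few. Any claim that something is new, unique, unknown or untested is made for them only; others in the source may bear on it.

Measured so far:
compound 1 `O=C(CCCCC1CCSS1)NCc1cn(CCCCOc2ccc3cc(-c4ccc(Br)cc4)c(=O)oc3c2)nn1`: 47.6%
compound 2 `CC(=O)c1cc2ccc(OCCCCCn3cc(CNC(=O)CCCCC4CCSS4)nn3)cc2oc1=O`: 18.2%

In a functional assay on PC-12 cells (Rattus norvegicus) for cytotoxicity, read by MTT assay, with stated times of 3 h and 2 h, tested at 50 uM (a lower number here means a weaker effect, a higher number a stronger effect of the compound at the concentration tested), compound 2 gives the lower of the two numbers, and compound 1 is higher by a margin beyond the scatter. Compound 3 `COc1ccc(-c2cc3ccc(OCCCCCn4cc(CNC(=O)CCCCC5CCSS5)nn4)cc3oc2=O)cc1OC` is not yet measured. It differs from compound 2 by 3,4-dimethoxyphenyl in place of acetyl on an aromatic carbon. Compound 1, which also carries a six-membered aromatic ring of carbon only rather than an acetyl group, gives 47.6% in this assay. On that basis the step of a number 21.8 percentage points higher from compound 2 to compound 3 (beyond the scatter) is expected to be an increase beyond the scatter. Compound 3 is expected to give about 40%, within 24% to 56%.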

Compound 3, a percentage reported as activity, at one concentration (the size of the read-out at that concentration, not a potency): 55%
Beside the measured number, compound 3's estimate is 15 percentage points below it, within the range that was stated.
By their numbers in this assay, from the lowest: compound 2; then compounds 1 and 3 (each within the scatter of the next).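

In this assay, for the compounds shown here, putting 3,4-dimethoxyphenyl in place of acetyl gives a number 36.8 percentage points higher from compound 2 to compound 3 (beyond the scatter) and provides the first reading of a single change on the shared core. It shows that the group on this aromatic carbon, two atoms from the ring oxygen, can alone shift the read-out by a large step. No available measurement explains this step.

From the compounds shown here alone, whether the step comes from the aromatic ring or from its two methoxy groups remains open, and a plain phenyl group here would separate the two. Going by these compounds, how an amine or a carboxylic acid at this position would read is also open.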